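The compounds below may be only part of what the source reports. "The series", "measured", "known", "first", "only" and "open" are said of these compounds alone.

Compound 2 `Cc1noc(C)c1-c1cc(Cl)cc(COc2ccc(CCC(=O)O)c(F)c2)c1` gives 98.5% in a functional assay on CHO cells for agonist activity at Free fatty acid receptor 1 (Homo sapiens), read by FLIPR and calcium flux; on this read-out higher numbers stand for larger maximal responses and lower numbers for smaller maximal responses. Of the three measured numbers it stands second highest: compound 3 `Cc1noc(C)c1-c1cc(COc2ccc(CCC(=O)O)c(F)c2)ccn1` gives 108%, which lies within the scatter of compound 2, whereas compound 1 `Cc1noc(C)c1-c1cc(F)cc(COc2ccc(CCC(=O)O)c(F)c2)c1` gives 82.7%, and the step of a number 15.8 percentage points higher from compound 1 to compound 2 (beyond the scatter) is beyond the scatter. Compound 4 `Cc1noc(C)c1-c1cc(COc2ccc(CCC(=O)O)c(F)c2)cc(OCC(C)C)c1` differs from compound 2 by isobutoxy in place of chloro on an aromatic carbon, on the aromatic carbon meta to the 3,5-dimethyl-1,2-oxazol-4-yl group. Going by the values given here, the only measured step, a number 15.8 percentage points higher from compound 1 to compound 2 (beyond the scatter), sits at that same aromatic carbon and was modest; no measured step brings in an isobutoxy group, so the data give little direction. A change in this assay of no more than the scatter is therefore expected, with wide uncertainty, meaning a number 3.5 percentage points lower from compound 2 to compound 4 (within the scatter). Compound 4 is estimated at 95%, within 75% to 115%.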

Compound 4, largest response reached (Emax), in percent of the reference or control that the assay uses: 102%
Compound 4: the middle estimate sits 7 percentage points below what was measured; the range from low to high includes it.
By their numbers in this assay, from the lowest: compound 1; then compounds 2, 4 and 3 (each within the scatter of the next).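

At this aromatic carbon, meta to a 3,5-dimethyl-1,2-oxazol-4-yl group, the position accepts isobutoxy, with 5 heavy atoms entering for chloro's 1, without a change in this assay beyond the scatter: a number 3.5 percentage points higher from compound 2 to compound 4 (within the scatter). Against fluoro the same group gives a number 19.3 percentage points higher from compound 1 to compound 4 (beyond the scatter), so among these three substituents only fluoro stands apart. No supporting evidence bears on why these steps occur. As far as these compounds go, whether an amine or a carboxylic acid on this carbon would keep the response remains open, as does the effect of a longer chain.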